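A Second Chloro on the Side Chain of Compound 3

The source may report more compounds than this note shows. Statements on the series, on what has been measured and on what is new or still open speak of the compounds shown alone.

Compound 3 `COc1ccc(/C=C2\CCC/C(=C\c3cccc(Cl)c3)C2=O)cc1OC` gives the lowest number of the three measured compounds in a functional assay on HT-1080 cells (Homo sapiens) for cytotoxicity, read by MTT assay, with a stated time of 72 h (on this read-out lower numbers stand for stronger inhibition and higher numbers for weaker inhibition), with 4900 nM. Compound 2 `COc1cccc(/C=C2\CCC/C(=C\c3ccc(O)c(Cl)c3)C2=O)c1OC` gives 14300 nM, and compound 1 `COc1cccc(/C=C2\CCC/C(=C\c3cccc(Cl)c3Cl)C2=O)c1OC` gives 19300 nM; both of these stand beyond the scatter from compound 3. Compound 4 `COc1ccc(/C=C2\CCC/C(=C\c3ccc(Cl)c(Cl)c3)C2=O)cc1OC` differs from compound 3 by chloro in place of hydrogen on an aromatic carbon. Going by the values given here, the only measured step, a 1.3-fold lower number from compound 1 to compound 2 (0.13 log units; within the scatter), exchanged one whole aryl group for another on the core of compound 1 and lies within the scatter; it does not isolate the entry of a single chloro, and no measured pair does. The expectation is therefore a step of no more than the scatter, a 1.2-fold lower number from compound 3 to compound 4 (0.09 log units; within the scatter), and compound 4 is estimated at 4000 nM, within 1500 nM to 11000 nM.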

Compound 4, half-maximal inhibitory concentration: 3100 nM
Estimate against measurement, compound 4: 1.3-fold (0.11 log units) above; low and high end bracket the measured number.
By their numbers in this assay, from the lowest: compounds 4 and 3 (each within the scatter of the next); then compounds 2 and 1 (each within the scatter of the next).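

Going by these compounds alone, this is the first step that isolates the entry of a single chloro: in this assay, 3-chlorophenyl becoming 3,4-dichlorophenyl, with the new chloro ortho to a chloro group and para to a large group, gives a 1.6-fold lower number from compound 3 to compound 4 (0.20 log units; within the scatter). This position therefore takes a chloro in place of hydrogen with no change beyond the scatter. Nothing available explains this result.

As far as these compounds go, whether an amine or a carboxylic acid on this same aromatic carbon would leave the number similarly unmoved stays open. So does whether the same chloro would behave alike on the core of compound 1.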